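The source may hold more compounds than are shown below. What is called first, only, known or untested is meant among the compounds shown, and "the series" means these compounds.

Of the compounds shown here, two with the shared core have been measured in an assay on isolated protein for inhibition of Amine oxidase [flavin-containing] B (Homo sapiens), read by fluorescence, with a stated time of 15 min; on this read-out lower numbers stand for stronger inhibition and higher numbers for weaker inhibition. Compound 1, `COc1ccc(/C=C/c2cc(OC)cc(OC)c2/C=C/C(=O)c2cc3ccc(Cl)cc3oc2=O)cc1`, gives 7360 nM in this assay. Compound 2, `COc1ccc(/C=C/c2cc(OC)cc(OC)c2/C=C/C(=O)c2cc3cc(Br)ccc3oc2=O)cc1`, reaches only the limit of the assay, > 60000 nM. The single measured step, an at least 8.1-fold higher number from compound 1 to compound 2 (0.91 log units; beyond the scatter), changes both the halogen and the place where it sits, and it leaves compound 2 at the weak end of the numbers shown, as the limit of > 60000 nM in this assay, at which 1 of the 2 values shown sits, records. Compound 3, `COc1ccc(/C=C/c2cc(OC)cc(OC)c2/C=C/C(=O)c2cc3cc(Cl)ccc3oc2=O)cc1`, differs from compound 2 by chloro in place of bromo on an aromatic carbon, meta to a fused ring and para to a fused ring. Within the data shown here, no measured step swaps one halogen for the other at the same place, so no size of step can be read off. In this assay the step is expected to be small, an at least 1.3-fold lower number from compound 2 to compound 3 (0.12 log units; that floor lies within the scatter). Compound 3 is therefore estimated at 45000 nM, with a range from 12000 nM to 150000 nM.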

Compound 3, half-maximal inhibitory concentration: > 60000 nM
Compound 3 was reported as a limit; the forecaster's own chance of this, stated with the estimate: 50%; middle value at least 1.3-fold (0.12 log units) from the limit.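

With the chloro group kept and only its place on the ring changed, this assay shows an at least 8.1-fold higher number from compound 1 to compound 3 (0.91 log units; beyond the scatter). The earlier step changed the halogen and its place together, whereas this one shows that the place alone is enough for a step beyond the scatter. Compound 3 is reported only as a limit, as is compound 2, so the step between them cannot be read and bromo and chloro at this place cannot be ranked, the two compounds sharing the same limit: the limit of > 60000 nM in this assay, at which 2 of the 3 values shown sit.

Going by these compounds, whether bromo at the place the chloro group holds in compound 1 would give a measurable number remains open. So does whether an amine or a carboxylic acid, meta to a fused ring and para to a fused ring, would give a reading inside the range of the assay.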